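Swapping hydroxy for nitro: a modest step expected

This account rests on a few compounds, and the source may have more. Where it says the series, first, only, none or still open, it means among the compounds named here.

Three compounds measured so far in a functional assay, with a stated time of 30 min; on this read-out higher numbers stand for weaker inhibition and lower numbers for stronger inhibition
- compound 1 `CCCCc1oc2ccc(/N=C/c3ccc(O)cc3)cc2c1C(=O)c1ccc(OC)cc1` gives 22.8 ug/mL
- compound 2 `CCCCc1oc2ccc(/N=C/c3ccc(Cl)cc3)cc2c1C(=O)c1ccc(OC)cc1` gives 75.9 ug/mL
- compound 3 `CCCCc1oc2ccc(/N=C/c3ccc(OC)cc3OC)cc2c1C(=O)c1ccc(OC)cc1` gives 20.5 ug/mL

Compound 1 sits in the lower pair of these three numbers. Its nearest neighbour shows a 1.1-fold lower number from compound 1 to compound 3 (0.05 log units; within the scatter) and is therefore not truly separated from it, while compound 2 stands clearly apart.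

Compound 4 `CCCCc1oc2ccc(/N=C/c3ccc([N+](=O)[O-])cc3)cc2c1C(=O)c1ccc(OC)cc1` has not been measured yet. Its change from compound 1 is nitro in place of hydroxy on an aromatic carbon, para to a large group, counted as nitro in place of hydroxy on an aromatic carbon with the rest of the molecule unchanged.

The closest guide is compound 2, where chloro takes the place of hydroxy at that same carbon and the data show a 3.3-fold higher number from compound 1 to compound 2 (0.52 log units; beyond the scatter) as a modest move toward weaker inhibition. Compound 3 goes against any simple rule that losing the hydroxy raises the number, since it also lacks that group and the data show a 1.1-fold lower number from compound 1 to compound 3 (0.05 log units; within the scatter) with no real change. Going by the values given here, no compound measured so far carries a nitro group, so this guidance is thin.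

A modest step toward a higher number in this assay is therefore expected, and the expected step is a 2.2-fold higher number from compound 1 to compound 4 (0.34 log units; beyond the scatter) on this estimate. Estimated for compound 4 is 50 ug/mL within an expected range of 18 ug/mL to 130 ug/mL in this read-out.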

Compound 4, half-maximal inhibitory concentration: 53.1 ug/mL
Compound 4: the middle estimate sits 1.1-fold (0.03 log units) below what was measured; the measured number falls inside the stated range.
By their numbers in this assay, from the lowest: compounds 3 and 1 (each within the scatter of the next); then compounds 4 and 2 (each within the scatter of the next).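

In this assay, nitro in place of hydroxy on this aromatic carbon gives a 2.3-fold higher number from compound 1 to compound 4 (0.37 log units; beyond the scatter) and so moves the number the same way as chloro did, which makes this a second replacement of the hydroxy that weakens inhibition. The two replacing groups are not truly separated here, since nitro in place of chloro gives a 1.4-fold lower number from compound 2 to compound 4 (0.16 log units; within the scatter) and stays within the scatter, so this small set cannot rank them against each other. Compound 3 still goes against a simple rule that losing the hydroxy raises the number: it also lacks that group, yet the change to the 4-nitrophenyl group gives a 2.6-fold higher number from compound 3 to compound 4 (0.41 log units; beyond the scatter) and leaves the 2,4-dimethoxyphenyl compound in the lower pair.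

Nothing measured here explains why the groups sort this way. From the compounds shown here alone, whether a single methoxy, an amine or a carboxylic acid on this carbon would fall with hydroxy or with chloro and nitro remains open, as does what each methoxy of compound 3 contributes on its own.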